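Two methoxy additions on a shared aryl-imidazole scaffold

The compounds below may be only part of what the source reports. "The series", "measured", "known", "first", "only" and "open" are said of these compounds alone.

Measured compounds:
- compound 1, `C=CCCCCOc1ccccc1-c1cnc(OCCC=C)n1C`: 9000 nM
- compound 2, `C=CCCCCOc1ccc(OC)cc1-c1cnc(OCCC=C)n1C`: 43000 nM
- compound 3, `C=CCCCCOc1ncc(-c2ccccc2OC)n1C`: 5000 nM

All three were tested in a functional assay on A549 cells (Homo sapiens) for inhibition, read by colorimetric assay and MTT assay, with a stated time of 72 h; on this read-out higher numbers stand for weaker inhibition and lower numbers for stronger inhibition. Compound 1 gives 9000 nM, and compound 2, which carries one extra group, gives 43000 nM. The change between them is methoxy in place of hydrogen on an aromatic carbon, and it produced a 4.8-fold higher number from compound 1 to compound 2 (0.68 log units; beyond the scatter). Compound 3 gives 5000 nM; the difference between its core and the core of compound 1 is not broken down here, and its value and that of compound 1 lie within the scatter of each other.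

Compound 4, `C=CCCCCOc1ncc(-c2cccc(OC)c2OC)n1C`, has not yet been measured in this assay. It arises from compound 3 through (methoxy in place of hydrogen on an aromatic carbon). This is the same kind of change as that from compound 1 to compound 2, but the surroundings differ: in compound 2 the new group sits meta to a large group and para to a (hex-5-en-1-yl)oxy group, whereas in compound 4 it sits ortho to a methoxy group and meta to a large group.

Among the measured compounds shown here, because the one measured example of this kind of change gave a 4.8-fold higher number from compound 1 to compound 2 (0.68 log units; beyond the scatter), compound 4 is expected to show a 3.6-fold higher number from compound 3 to compound 4 (0.56 log units; beyond the scatter), a step of roughly similar size but less certain given the different surroundings. Compound 4 is therefore estimated at 18000 nM, expected to fall between 6000 nM and 60000 nM.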

Compound 4, half-maximal inhibitory concentration: 43000 nM
Compound 4: the middle estimate sits 2.4-fold (0.38 log units) below what was measured, within the range that was stated.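

In this assay, methoxy in place of hydrogen on an aromatic carbon again raised the number, with an 8.6-fold higher number from compound 3 to compound 4 (0.93 log units; beyond the scatter). Set beside the earlier step, this one points the same way, and the gap between the two is no larger than repeated measurements would allow, so the change carried over from one core to the other with a similar size: the same change on two cores in this assay, a 4.8-fold higher number (0.68 log units; beyond the scatter) from compound 1 to compound 2 and an 8.6-fold higher number (0.93 log units; beyond the scatter) from compound 3 to compound 4, 1.8-fold (0.26 log units) apart, within the scatter of two such steps

Among the compounds shown here, this agreement rests on only two pairs of compounds, with the new group in different surroundings in each, so it is no rule for the whole series and says nothing about why the number rises.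

The compounds shown leave open whether this rise belongs to the methoxy group itself or would also appear with another group in its place, such as a hydroxyl group, a fluorine atom or an amine. They also leave open whether the step would keep its size at other places on the ring or with a shorter chain in place of the (hex-5-en-1-yl)oxy group.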